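A few compounds are considered here, and "the series" means these few. Any claim that something is new, unique, unknown or untested is made for them only; others in the source may bear on it.

In a physicochemical assay for solubility, read by spectrophotometry, in phosphate buffer, with a stated time of 18 h, at pH 7.4 (a lower number here means a less soluble compound, a higher number a more soluble compound), the three measured compounds read as follows.
Compound 1 (`CCc1ccc(-c2nc3c(c(C)nn3-c3ccccc3)c(-c3ccccc3[N+](=O)[O-])c2C#N)cc1`) gives 1200 nM
Compound 2 (`CCc1ccc(-c2nc3c(c(C)nn3-c3ccccc3)c(-c3ccccc3Br)c2C#N)cc1`) gives 1500 nM
Compound 3 (`CCc1ccc(-c2nc3c(c(C)nn3-c3ccccc3)c(-c3ccccc3S(C)(=O)=O)c2C#N)cc1`) gives 2200 nM

Compound 3 stands within the scatter of both other compounds (a 1.8-fold higher number from compound 1 to compound 3 (0.26 log units; within the scatter); a 1.5-fold higher number from compound 2 to compound 3 (0.17 log units; within the scatter)). The next compound is compound 4 (`CCc1ccc(-c2nc3c(c(C)nn3-c3ccccc3)c(-c3ccccc3C(F)(F)F)c2C#N)cc1`), which carries trifluoromethyl in place of methylsulfonyl on an aromatic carbon. Within the data shown here, no measured step makes this exact exchange. The evidence comes from the other exchanges on this carbon, and the remaining one, bromo in place of nitro (a 1.3-fold higher number from compound 1 to compound 2 (0.10 log units; within the scatter)), also stays within the scatter. The exchange that also removes methylsulfonyl is the one between the bromo and methylsulfonyl compounds (a 1.5-fold higher number from compound 2 to compound 3 (0.17 log units; within the scatter)), and on that ground no change beyond the scatter is expected in this assay. A slightly lower number is expected, with the estimate reading a 1.5-fold lower number from compound 3 to compound 4 (0.17 log units; within the scatter) and nothing more than that. Compound 4 is expected at 1500 nM (estimated range 750 nM to 3000 nM).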

Compound 4, solubility: 11000 nM
Compound 4: the middle estimate sits 7.3-fold (0.87 log units) below what was measured; measured number above the stated range.
By their numbers in this assay, from the lowest: compounds 1, 2 and 3 (each within the scatter of the next); then compound 4.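

At this place, on an aromatic carbon ortho to a large group, exchanges among nitro, bromo and methylsulfonyl had all stayed within the scatter in this assay, and trifluoromethyl is the first group shown to move the number beyond it (a 5.0-fold higher number from compound 3 to compound 4 (0.70 log units; beyond the scatter); a 7.3-fold higher number from compound 2 to compound 4 (0.87 log units; beyond the scatter); a 9.2-fold higher number from compound 1 to compound 4 (0.96 log units; beyond the scatter)). The position therefore does respond to the group it carries, with compound 4 standing apart from compounds 1, 2 and 3, even though methylsulfonyl and trifluoromethyl have the same count of heavy atoms. Nothing available bears on what lies behind this step. The compounds shown leave open whether the rise is particular to trifluoromethyl or is shared by other groups here, such as a methyl, a methoxy or an amine. They also leave open whether it would persist with a different group in place of the 4-ethylphenyl or the nitrile on the shared core.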